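The source may hold more compounds than are shown below. What is called first, only, known or untested is meant among the compounds shown, and "the series" means these compounds.

Measured in a functional assay on the whole organism (integument) for inhibition, with Chilo suppressalis as the target, read by scintillation counting, with a stated time of 72 h; a lower number here means a stronger inhibitor, a higher number a weaker inhibitor:

- compound 1 `O=C(Nc1nnc(-c2ccc(Cl)cc2)s1)c1c(F)cccc1F`: > 5010 nM, a limit of this assay, not a number
- compound 2 `COc1cccc(OC)c1C(=O)Nc1nnc(-c2ccc(Cl)cc2)s1`: 58.9 nM
- compound 3 `O=C(Nc1nnc(-c2ccc(Cl)cc2)s1)c1ccccc1I`: > 5010 nM, a limit of this assay, not a number

Among the measured compounds shown here, compound 2 carries the only actual number among the three; the other two sit at a limit, as noted in the limit of > 5010 nM in this assay, at which 2 of the 3 values shown sit. For the measured compounds named here, no pair of measured compounds differs in one place, so no measured step is available.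

Compound 4 `COc1cccc(OC)c1C(=O)Nc1nnc(-c2ccc(-c3ccccc3)cc2)s1` has not been tested. It differs from compound 2 by phenyl in place of chloro on an aromatic carbon. The shared core is unchanged; the two dimethoxy-bearing rings match. Without a measured step of this kind in the series, the direction is unknown, and a step of moderate size in this assay in either direction is as plausible as none beyond the scatter. The working expectation is that the step from compound 2 to compound 4 is a 2.0-fold higher number from compound 2 to compound 4 (0.31 log units; beyond the scatter), a small loss. Compound 4 is expected to give about 120 nM, with a range from 20 nM to 800 nM.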

Compound 4, half-maximal inhibitory concentration: 195 nM
For compound 4 the middle estimate is 1.6-fold (0.21 log units) below the measured one, and the stated range covers the measured number.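

In this assay, phenyl in place of chloro on this aromatic carbon, para to a large group, gives a 3.3-fold higher number from compound 2 to compound 4 (0.52 log units; beyond the scatter). Among the compounds shown here, this is the first measured step, and it shows that this position tolerates an added six-membered aromatic ring of carbon only with a modest loss, not a collapse to the limit of the assay. Nothing among the data shown gives a cause for this step.

With only chloro and phenyl measured at this position, a single step sets no trend, and no pattern can be claimed for other groups. As far as these compounds go, whether an amine, a carboxylic acid or a longer alkyl chain at the same position would keep, improve or lose the number stays open.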